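The source may hold more compounds than are shown below. What is called first, only, known or untested is meant among the compounds shown, and "the series" means these compounds.

Of the compounds shown here, three built on a shared core have been measured in an ADME assay on the whole organism (Mus musculus, strain CD1) for pharmacokinetics, read by LC-MS, using cassette dosing, with a stated time of 24 h, at a dose of 0.4 mg/kg by the intravenous route; on this read-out higher numbers stand for wider distribution into tissues and lower numbers for narrower distribution. Compound 1 `Cc1cn(-c2cc(NC(=O)c3ccc(C)c(Nc4nccc(-c5ccccc5)n4)c3)cc(N3CCNCC3)c2)cn1` gives 3.74 L/kg. For the measured compounds named here, compound 2 `Cc1cn(-c2cc(CN3CCN(C)CC3)cc(NC(=O)c3ccc(C)c(Nc4nccc(-c5ccccc5)n4)c3)c2)cn1` gives 5.65 L/kg in this assay, and the move a 1.5-fold higher number from compound 1 to compound 2 (0.18 log units; within the scatter) is the only step between measured compounds that differ in a single place. Compound 3 `Cc1cn(-c2cc(NC(=O)c3ccc(C)c(Oc4ccccc4)c3)cc(N3CCN(C)CC3)c2)cn1` gives 9.26 L/kg in this assay, the highest of the three numbers; its gap to compound 2 lies within the scatter, while its gap to compound 1 lies beyond it. Going by the values given here, compound 3 differs from each of those two compounds in more than one place, so no single step can be drawn from either pair.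

Compound 4 `Cc1cn(-c2cc(NC(=O)c3ccc(C)c(C(=O)c4cccc(C#N)c4)c3)cc(N3CCN(C)CC3)c2)cn1` is compound 3 with (3-cyanophenyl)carbonyl in place of phenoxy on an aromatic carbon. Among the compounds with values here, no measured step touches this part of the molecule: the one available step, from compound 1 to compound 2, concerns a different group altogether and was within the scatter, so it offers no guide to the size or direction of the present change. Lacking a comparable step, compound 4 is expected to show a modest downward move a 1.3-fold lower number from compound 3 to compound 4 (0.12 log units; within the scatter) in this assay, one that may well fall within the scatter. The estimate for compound 4 in this assay is 7 L/kg, with a range from 3.5 L/kg to 14 L/kg.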

Compound 4, volume of distribution at steady state: 4.7 L/kg
For compound 4 the middle estimate is 1.5-fold (0.17 log units) above the measured one; the range from low to high includes it.
By their numbers in this assay, from the lowest: compounds 1, 4, 2 and 3 (each within the scatter of the next, the first and the last beyond it).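

In this assay, putting (3-cyanophenyl)carbonyl in place of phenoxy on the aromatic carbon ortho to a methyl group gives a 2.0-fold lower number from compound 3 to compound 4 (0.29 log units; within the scatter), the only measured step at this position among the compounds shown. The step shows that this carbon can carry a group with more heavy atoms, one that brings a carbonyl and a nitrile with it, while the read-out stays within the scatter of repeated measurements, so no real effect of the exchange can be claimed. No measured information bears on what lies behind the size of this step.

The compounds shown leave open which part of the exchange matters, since the carbonyl link and the nitrile enter together; a plain benzoyl group or a phenylamino group on the same carbon would help to separate the two. As far as these compounds go, it also remains open whether a carboxylic acid or an aminomethyl group in place of the nitrile would carry the number in this assay beyond the scatter.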